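From 4-fluorobenzyl to 2-fluorobenzyl at the shared core

The source may hold more compounds than are shown below. What is called first, only, known or untested is meant among the compounds shown, and "the series" means these compounds.

In a functional assay on PC-3 cells (Homo sapiens) for cytotoxicity, read by MTT assay, with a stated time of 24 h (a higher number here means a weaker inhibitor, a lower number a stronger inhibitor), compound 1 (`COc1ccc(/C=C2\CN(C(=S)SCc3cn(Cc4ccc(F)cc4)nn3)C/C(=C\c3ccc(OC)cc3)C2=O)cc1`) gives 45600 nM and compound 2 (`COc1ccc(/C=C2\CN(Cc3cn(Cc4ccc(F)cc4)nn3)C/C(=C\c3ccc(OC)cc3)C2=O)cc1`) gives 67500 nM with these two values lying within the scatter of each other. Compound 3 (`COc1ccc(/C=C2\CN(Cc3cn(Cc4ccccc4F)nn3)C/C(=C\c3ccc(OC)cc3)C2=O)cc1`) has one change from compound 2 (2-fluorophenyl in place of 4-fluorophenyl on a saturated chain carbon bound to an aromatic nitrogen) with 2-fluorophenyl in place of 4-fluorophenyl on a saturated chain carbon bound to an aromatic nitrogen. Among the compounds with values here, no measured step shows what such a change does, so no shift beyond the scatter is expected in this assay. The expected step (a 1.2-fold lower number from compound 2 to compound 3 (0.09 log units; within the scatter)) is therefore small. Compound 3 is estimated at 55000 nM (range 28000 nM to 100000 nM).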

Compound 3, half-maximal inhibitory concentration: 39900 nM
Compound 3: middle estimate off by 1.4-fold (0.14 log units), on the high side, and the stated range covers the measured number.
By their numbers in this assay, from the lowest: compounds 3, 1 and 2 (each within the scatter of the next).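

In this assay, within the data shown here, the exchange of 4-fluorophenyl for 2-fluorophenyl on a saturated chain carbon bound to an aromatic nitrogen gives a 1.7-fold lower number from compound 2 to compound 3 (0.23 log units; within the scatter) and is the first measured step at this position. It shows that these two fluorophenyl groups cannot be told apart in this assay. The compounds shown leave open whether unsubstituted phenyl or a longer chain at this place would give a step beyond the scatter. No measured evidence bears on what lies behind this result.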